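Methoxy for fluoro: from compound 3 to compound 4

The source may report more compounds than this note shows. Statements on the series, on what has been measured and on what is new or still open speak of the compounds shown alone.

Compound 3 `O=C(O)CN1C(=O)/C(=C/c2nc3ccc(F)cc3n2Cc2ccccc2F)SC1=S` gives only a limit in a functional assay on MDA-MB-231 cells (Homo sapiens) for cytotoxicity, read by MTT assay, with a stated time of 48 h (a higher number here means a weaker inhibitor, a lower number a stronger inhibitor), > 50000 nM; this is the limit of > 50000 nM in this assay, at which 1 of the 3 values shown sits. Compound 1 `O=C(O)CN1C(=O)/C(=C/c2nc3ccccc3n2Cc2ccccc2F)SC1=S` gives 330 nM in this assay. Going by the values given here, the one measured step bearing on the change is an at least 150-fold higher number from compound 1 to compound 3 (2.18 log units; beyond the scatter), with fluoro in place of hydrogen on an aromatic carbon. Compound 4 `COc1ccc2nc(/C=C3\SC(=S)N(CC(=O)O)C3=O)n(Cc3ccccc3F)c2c1` differs from compound 3 by methoxy in place of fluoro on an aromatic carbon, so that fluoro leaves and methoxy enters. Compound 2 `COc1ccc2nc(/C=C3\SC(=S)N(CC(=O)O)C3=O)n(Cc3ccc(C)cc3)c2c1`, which also carries methoxy, gives 3770 nM. A large step towards a lower number is therefore expected, estimated as an at least 16-fold lower number from compound 3 to compound 4 (1.22 log units; beyond the scatter). The expected value for compound 4 is 3000 nM, with an estimated range of 600 nM to 20000 nM.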

Compound 4, half-maximal inhibitory concentration: 22400 nM
Compound 4: the middle estimate sits 7.5-fold (0.87 log units) below what was measured; the measured number lies above the stated range.
By their numbers in this assay, from the lowest: compound 1; then compound 2; then compound 4. At a limit, above all of these: compound 3.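

Replacing hydrogen with methoxy on this aromatic carbon also brings a loss, a 68-fold higher number from compound 1 to compound 4 (1.83 log units; beyond the scatter), so the loss seen at this position is not confined to fluoro. Methoxy in place of fluoro gives an at least 2.2-fold lower number from compound 3 to compound 4 (0.34 log units; beyond the scatter), a step with only a bound on its size, as compound 3 stands at a limit: the limit of > 50000 nM in this assay, at which 1 of the 4 values shown sits.
With methoxy kept, the group on the saturated chain carbon also counts: 2-fluorophenyl in place of 4-methylphenyl gives a 5.9-fold higher number from compound 2 to compound 4 (0.77 log units; beyond the scatter).

Still open, from the compounds shown here alone, is whether any group here, such as chloro or an amine, keeps the level of compound 1. Also open, going by these compounds, is how 4-methylphenyl behaves on the core of compound 1.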